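Amide-linked phenols: isopropyl to methyl step

The compounds below may be only part of what the source reports. "The series", "measured", "known", "first", "only" and "open" are said of these compounds alone.

Measured so far:
Compound 1 `CC(C)(C)c1cc(OC(=O)c2ccc([N+](=O)[O-])cc2Cl)ccc1O` gives 8800 nM in this assay.
Compound 2 `CC(C)c1cc(NC(=O)c2ccc(Cl)cc2Cl)ccc1O` returns only a limit of the assay, > 100000 nM.

Both values come from an assay on isolated protein for antagonist activity at Bile acid receptor (Homo sapiens), read by HTRF, with a stated time of 30 min; on this read-out higher numbers stand for weaker inhibition and lower numbers for stronger inhibition. Compound 2 therefore stands at the limit (the limit of > 100000 nM in this assay, at which 1 of the 2 values shown sits), with no number attached; the value of compound 1 lies well inside the measurable range, while that of compound 2 does not.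

Compound 3 `Cc1cc(NC(=O)c2ccc(Cl)cc2Cl)ccc1O` differs from compound 2 by methyl in place of isopropyl on an aromatic carbon. Within the data shown here, no measured pair of compounds shows this change, so the size of the step cannot be read from the data. The expectation is a step that the limit leaves unreadable from compound 2 to compound 3, that is, nothing beyond the scatter, with compound 3 most likely again reported only as a limit. Compound 3 is accordingly estimated at 150000 nM, in a range from 30000 nM to 600000 nM.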

Compound 3, half-maximal inhibitory concentration: > 100000 nM
Compound 3 was reported as a limit; the forecaster's own chance of this, stated with the estimate: 75%; the middle value lies beyond the limit too.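

Compound 2 and compound 3 both return only a limit, so no step can be read between them: the limit of > 100000 nM in this assay, at which 2 of the 3 values shown sit.

The compounds shown leave open whether methyl in place of isopropyl on an aromatic carbon changes inhibition at all in these amide-linked phenols.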